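Cytotoxicity limits across the alkyl series on the core

The compounds below may be only part of what the source reports. "The series", "measured", "known", "first", "only" and "open" are said of these compounds alone.

Compound 2 `CCCC1(Cc2ccccc2)OS(=O)(=O)C=C1OCc1ccccc1` and compound 1 `CC(C)C1(Cc2ccccc2)OS(=O)(=O)C=C1OCc1ccccc1` share one core and differ in the alkyl group on a saturated ring carbon, propyl in place of isopropyl. In an ADME assay on HEL cells (Homo sapiens) for cytotoxicity, with a stated time of 3 days (on this read-out lower numbers stand for higher toxicity in this test and higher numbers for lower toxicity in this test), compound 1 reaches only a limit, >= 80000 nM. In this assay compound 2 likewise gives only a limit, >= 400000 nM. Both readings are limits, so a step that the two limits leave unreadable from compound 1 to compound 2 cannot be read as a number; each of the two values shown sits at one of the two limits, the limit of >= 400000 nM in this assay, at which 1 of the 2 values shown sits, and (the limit of >= 80000 nM in this assay, at which 1 of the 2 values shown sits). Compound 2 therefore stands at a limit in this assay and nowhere more exactly.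

Compound 3 `CC1(Cc2ccccc2)OS(=O)(=O)C=C1OCc1ccccc1` differs from compound 2 by hydrogen in place of ethyl on a saturated chain carbon bound to a saturated ring carbon. For the measured compounds named here, the only measured step, a step that the two limits leave unreadable from compound 1 to compound 2, is unreadable and concerns another change, so no measured step bears on this one in size; the two values show only that neither compound 1 nor compound 2 gives a number in this assay. No shift beyond the scatter is expected in either direction. Compound 3 is expected at 300000 nM in this assay, within 80000 nM to 400000 nM, most likely again reported as a limit. The expected step is an at least 1.3-fold lower number from compound 2 to compound 3 (0.12 log units; that floor lies within the scatter).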

Compound 3, minimum cytotoxic concentration: > 400000 nM
Compound 3: no number, only a limit (the forecaster's own chance of this, stated with the estimate: 85%); at least 1.3-fold (0.12 log units) between middle value and limit.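

In this assay compound 3 gives only a limit, > 400000 nM. For the compounds shown here, compound 1, compound 2 and compound 3 all stand at limits, so no step among them can be read. The compounds shown leave open whether the alkyl group on the saturated ring carbon changes the minimum cytotoxic concentration in this assay at all, and by how much.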